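A few compounds are considered here, and "the series" means these few. Any claim that something is new, unique, unknown or untested is made for them only; others in the source may bear on it.

Measured in an ADME assay on microsomes from liver (Rattus norvegicus) for metabolic stability (on this read-out lower numbers stand for a shorter-lived compound and higher numbers for a longer-lived compound), each value a limit and not a number:

Compound 1 `Nc1nc(NCCNc2ncc(-c3ncc[nH]3)c(-c3ccccc3Cl)n2)ccc1[N+](=O)[O-]`: > 0.5 h
Compound 2 `Nc1nc(NCCNc2ncc(-c3ncc[nH]3)c(-c3cc(F)ccc3F)n2)ccc1[N+](=O)[O-]`: > 0.5 h
Compound 3 `Nc1nc(NCCNc2ncc(-c3ncc[nH]3)c(-c3ccc(F)cc3Br)n2)ccc1[N+](=O)[O-]`: > 0.5 h

In this assay compound 3 stands only at a limit, > 0.5 h, so no exact half-life is known for it. The same is true of compound 1 and compound 2, and the whole evidence so far is the limit of > 0.5 h in this assay, at which 3 of the 3 values shown sit.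

Compound 4 `Nc1nc(NCCNc2ncc(-c3ncc[nH]3)c(-c3ccc(F)cc3C(F)(F)F)n2)ccc1[N+](=O)[O-]` keeps the shared core and differs from compound 3 in one group: trifluoromethyl in place of bromo on an aromatic carbon. The new group sits in the same place, on an aromatic carbon, ortho to a large group and meta to a fluoro group.

Within the data shown here, three measured steps bear on this change, since each swaps the groups on the same phenyl: a step that the two limits leave unreadable from compound 1 to compound 2, a step that the two limits leave unreadable from compound 1 to compound 3 and a step that the two limits leave unreadable from compound 2 to compound 3. None of them has a readable size, so they point in no direction, and no step beyond the usual scatter is expected in this assay. The expected change is a step that the limit leaves unreadable from compound 3 to compound 4. Another result reported only as a limit is the most likely outcome. The estimate for compound 4 is 0.8 h, expected to lie between 0.5 h and 2 h.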

Compound 4, half-life: > 0.5 h
Compound 4 was reported as a limit (the forecaster's own chance of this, stated with the estimate: 85%); the middle value is on the limit's open side.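

Compound 4 is again reported only as a limit in this assay, so its steps from compound 1, compound 2 and compound 3 cannot be read, and the evidence now stands as: the limit of > 0.5 h in this assay, at which 4 of the 4 values shown sit. The compounds shown leave open the actual half-life of each one, and whether swapping the groups on the phenyl changes it at all.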